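Replacing the Oxetanyl Amide of Compound 1

This account rests on a few compounds, and the source may have more. Where it says the series, first, only, none or still open, it means among the compounds named here.

Compound 1 `CCN(CC)S(=O)(=O)c1ccc(S(=O)(=O)N2CCC[C@@H](C(=O)NC3COC3)C2)cc1` gives 2340 nM in a functional assay on MIA PaCa-2 cells (Homo sapiens) for inhibition, read by MTT assay, with a stated time of 7 days (on this read-out lower numbers stand for stronger inhibition and higher numbers for weaker inhibition), the highest of the three numbers measured; compound 3 `O=C([C@@H]1CCCN(S(=O)(=O)c2ccc(S(=O)(=O)N3CC[C@H](O)C3)cc2)C1)N1CCC(F)(F)CC1` gives 590 nM and compound 2 `CC(C)S(=O)(=O)c1ccc(S(=O)(=O)N2CCC[C@@H](C(=O)N3CCC(F)(F)CC3)C2)cc1` gives 11 nM. Compound 4 `CCN(CC)S(=O)(=O)c1ccc(S(=O)(=O)N2CCC[C@@H](C(=O)N3CCC(C(F)F)CC3)C2)cc1` differs from compound 1 in one place: 4-(difluoromethyl)piperidin-1-yl in place of (oxetan-3-yl)amino on a carbonyl carbon. For the measured compounds named here, no measured step covers this amide change; the only step, a 54-fold higher number from compound 2 to compound 3 (1.73 log units; beyond the scatter), concerns the sulfonyl group instead. Still, compounds 2 and 3, whose amide portion is closer to that of compound 4, show the lower numbers, so a lower number is expected for compound 4 in this assay, roughly a 9.4-fold lower number from compound 1 to compound 4 (0.97 log units; beyond the scatter), though the size is uncertain. The estimate for compound 4 is 250 nM, within 50 nM to 1200 nM.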

Compound 4, half-maximal inhibitory concentration: 420 nM
The estimate for compound 4 lay 1.7-fold (0.23 log units) below the measured number; the measured number falls inside the stated range.
By their numbers in this assay, from the lowest: compound 2; then compounds 4 and 3 (each within the scatter of the next); then compound 1.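

For the compounds shown here, this is the first measured change at the amide position, and it shows that this position matters with the sulfonyl side held constant: in this assay, 4-(difluoromethyl)piperidin-1-yl in place of (oxetan-3-yl)amino on the carbonyl carbon gives a 5.6-fold lower number from compound 1 to compound 4 (0.75 log units; beyond the scatter). Going by these compounds alone, the change swaps the four-membered ring for a six-membered one and also removes the amide hydrogen, so the single step cannot separate these differences. Nothing available accounts for the step.

From the compounds shown here alone, how an unsubstituted piperidin-1-yl or a morpholin-4-yl would read on the same carbonyl carbon remains open. So does whether the step carries over to the sulfonyl groups of compound 2 and compound 3.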